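This account rests on a few compounds, and the source may have more. Where it says the series, first, only, none or still open, it means among the compounds named here.

In a functional assay on HCT-116 cells (Homo sapiens) for inhibition, read by MTT assay, with a stated time of 48 h (a lower number here means a stronger inhibitor, a higher number a weaker inhibitor), compound 1 `COc1ccc(-n2c(SC)nnc2-c2cc(OC)c(OC)c(OC)c2)cc1` gives > 60000 nM and that is only a limit. Compound 3 `COc1ccc(-n2c(SCC(=O)c3ccccc3)nnc2-c2cc(OC)c(OC)c(OC)c2)cc1` gives > 60000 nM as a limit too, so it stands at the limit of > 60000 nM in this assay, at which 2 of the 3 values shown sit, and has no number of its own. Compound 2 `COc1ccc(-n2c(SCc3ccc(C)cc3)nnc2-c2cc(OC)c(OC)c(OC)c2)cc1` alone gives a number, 33300 nM in this set. The change to compound 4 `COc1ccc(-n2c(SCC(=O)c3ccc4ccccc4c3)nnc2-c2cc(OC)c(OC)c(OC)c2)cc1` is this one: naphthalen-2-yl in place of phenyl on a carbonyl carbon. The steps bearing on it are an at least 1.8-fold lower number from compound 1 to compound 2 (0.25 log units; that floor lies within the scatter) and an at least 1.8-fold higher number from compound 2 to compound 3 (0.25 log units; that floor lies within the scatter) and neither floor clears the scatter, whereas a step that the two limits leave unreadable from compound 1 to compound 3 gives no size. The estimated change is an at least 1.3-fold lower number from compound 3 to compound 4 (0.12 log units; that floor lies within the scatter) and it is expected to be small, toward lower numbers if readable at all. Compound 4 is expected at 45000 nM with a range from 18000 nM to 100000 nM in this assay as estimated here.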

Compound 4, half-maximal inhibitory concentration: > 60000 nM
Compound 4 gave a limit, no number; the forecaster's own chance of this, stated with the estimate: 55%; middle value at least 1.3-fold (0.12 log units) from the limit.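

Naphthalen-2-yl in place of phenyl on a carbonyl carbon does not bring this position off its limit: in this assay compound 4 gives > 60000 nM, which is only a limit. Among these compounds, the steps with a limit at both ends cannot be read, and the one readable step is an at least 1.8-fold higher number from compound 2 to compound 4 (0.25 log units; that floor lies within the scatter). The larger aromatic group thus leaves the set at the same ceiling: the limit of > 60000 nM in this assay, at which 3 of the 4 values shown sit.

Going by these compounds, whether naphthalen-2-yl differs from phenyl here at all stays open. So does whether an amine or a carboxylic acid on the carbonyl carbon would give a number.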